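Swapping the aryl group on the amide nitrogen

The compounds below may be only part of what the source reports. "The series", "measured", "known", "first", "only" and "open" are said of these compounds alone.

Compound 3 `CN(C)C(=O)c1cc2cnc(Nc3ccc(NC(=O)C4(C(=O)Nc5ccc(Cl)c(C(F)(F)F)c5)CC4)cc3)nc2n1C1CCCC1` gives 90.4% in a functional assay on NCI-H1299 cells (Homo sapiens) for inhibition, read by CCK-8 assay, with a stated time of 72 h, tested at 10 uM (on this read-out lower numbers stand for less inhibition of growth and higher numbers for more inhibition of growth at the one concentration tested), the highest of the three numbers measured. Compound 1 `CN(C)C(=O)c1cc2cnc(Nc3ccc(NC(=O)C4(C(=O)Nc5ccccc5F)CC4)cc3)nc2n1C1CCCC1` gives 89.6%, which is a number 0.8 percentage points higher from compound 1 to compound 3 (within the scatter), so these two cannot be told apart. Compound 2 `CN(C)C(=O)c1cc2cnc(Nc3ccc(NC(=O)C4(C(=O)Nc5ccc(Br)cc5)CC4)cc3)nc2n1C1CCCC1` gives 76.9%, and the step of a number 13.5 percentage points higher from compound 2 to compound 3 (beyond the scatter) is beyond the scatter; the step of a number 12.7 percentage points lower from compound 1 to compound 2 (beyond the scatter) points the same way.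

Compound 4 `CN(C)C(=O)c1cc2cnc(Nc3ccc(NC(=O)C4(C(=O)Nc5cccc(Cl)c5)CC4)cc3)nc2n1C1CCCC1` differs from compound 3 in one place: 3-chlorophenyl in place of 4-chloro-3-(trifluoromethyl)phenyl on an amide-type nitrogen. All three measured steps change this same aryl group on the amide nitrogen, so all bear on it. Two aryl groups, one bearing fluorine and one bearing chlorine with trifluoromethyl, gave numbers that agree, while the 4-bromophenyl case gave a modestly lower number. Since the 3-chlorophenyl group carries a single halogen, as the 4-bromophenyl group does, a small drop is expected rather than a rise, though one may also fall within the scatter. Compound 4 is therefore estimated at 83%, between 70% and 93%, an expected step of a number 7.4 percentage points lower from compound 3 to compound 4 (within the scatter).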

Compound 4, percent growth inhibition at one concentration: 84.1%
Compound 4: the middle estimate sits 1.1 percentage points below what was measured; the range from low to high includes it.
By their numbers in this assay, from the lowest: compounds 2, 4, 1 and 3 (each within the scatter of the next, the first and the last beyond it).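

Replacing 4-chloro-3-(trifluoromethyl)phenyl with the smaller 3-chlorophenyl, which takes the group on the amide-type nitrogen from 11 heavy atoms to 7, stays within the scatter in this assay (a number 6.3 percentage points lower from compound 3 to compound 4 (within the scatter)). Compound 4 is also within the scatter of the other two aryl cases (a number 7.2 percentage points higher from compound 2 to compound 4 (within the scatter)) and (a number 5.5 percentage points lower from compound 1 to compound 4 (within the scatter)). The earlier gap therefore no longer splits these aryl groups into two clear sets, since compound 4 links compound 2 to both compound 1 and compound 3, even though compound 2 and compound 3 remain beyond the scatter of each other. No measurement here explains these numbers.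

Still open, from the compounds shown here alone, is whether a phenyl ring carrying an amine or a carboxylic acid would give a similar number. The same question applies to a cyclohexyl ring on this nitrogen.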